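The source may hold more compounds than are shown below. What is called first, only, known or untested is meant among the compounds shown, and "the series" means these compounds.

Values so far in a physicochemical assay for solubility, measured as kinetic solubility (on this read-out lower numbers stand for lower solubility and higher numbers for higher solubility), are these:

- compound 1 `COc1cc(C)[nH]c(=O)c1CN1CCc2c(Cl)cc(-c3c(C)noc3C)c(Cl)c2C1=O` gives 384000 nM
- compound 2 `COC(c1cc(Cl)c2c(c1Cl)C(=O)N(Cc1c(C)cc(C)[nH]c1=O)CC2)C1CCN(C(=O)CO)CC1` gives 508000 nM; 513000 nM (2 entries)

Among the measured compounds shown here, compound 1 holds the only single number in the set. The repeat readings of compound 2 (the several entries of compound 2 in this assay, 508000 nM; 513000 nM (2 entries)) agree with each other, and its value lies within the usual scatter of the value of compound 1.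

Next comes compound 3 `COc1cc(C)[nH]c(=O)c1CN1CCc2c(Cl)cc([C@@H](O)C3COC3)c(Cl)c2C1=O`, not yet measured. Compared with compound 1, the 3,5-dimethyl-1,2-oxazol-4-yl group on an aromatic carbon gives way to a group with one four-membered non-aromatic ring and 1 defined stereocentre (a group of 6 heavy atoms (4 carbon, 2 oxygen; one four-membered non-aromatic ring with 1 hetero atom) in place of a group of 7 heavy atoms (5 carbon, 1 nitrogen, 1 oxygen; one five-membered aromatic ring with 2 hetero atoms), on an aromatic carbon).

For the measured compounds named here, no measured step covers this change, so the expectation rests on the values alone. Compound 1 at 384000 nM and compound 2 at 508000 nM; 513000 nM (2 entries) sit within the usual scatter of each other, and no shift beyond that scatter is expected in this assay for this change. The estimated 1.1-fold higher number from compound 1 to compound 3 (0.05 log units; within the scatter) is expected to stay within the scatter in either direction. For compound 3 the expected value is 430000 nM with an estimated range of 220000 nM to 760000 nM for the coming measurement.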

Compound 3, solubility: 582000 nM
Beside the measured number, compound 3's estimate is 1.4-fold (0.13 log units) below it, within the range that was stated.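

The first step read at this position in this assay is a 1.5-fold higher number from compound 1 to compound 3 (0.18 log units; within the scatter), so the read-out does not separate the two groups on this aromatic carbon, ortho to a chloro group. The change replaces 3,5-dimethyl-1,2-oxazol-4-yl, with its five-membered aromatic ring and 0 hydrogen-bond donors, by a group with one four-membered non-aromatic ring, 1 hydrogen-bond donor and 1 defined stereocentre, so compounds with two quite different groups at this place remain within the scatter of each other. The step is read against repeat readings in this assay that agree closely: the several entries of compound 2 in this assay, 508000 nM; 513000 nM (2 entries)

The compounds shown leave open whether an amine or a carboxylic acid on this aromatic carbon would give a step beyond the scatter in this assay. They also leave open whether the opposite configuration at the defined stereocentre of compound 3 would read the same, and a single step cannot show how far the tolerance at this position extends.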